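The source may hold more compounds than are shown below. What is called first, only, known or untested is meant among the compounds shown, and "the series" means these compounds.

Measured so far in a physicochemical assay for lipophilicity, using the shake flask method, in phosphate buffer, measured as octanol-water partition, with a stated time of 30 min, at pH 7.4; on this read-out lower numbers stand for lower lipophilicity and higher numbers for higher lipophilicity:
- compound 1 `CN(C(=O)c1ccccc1)c1cnc(NCc2c(F)ccc3c2CCO3)n2cnnc12`: 2.4
- compound 2 `O=C(Nc1cnc(NCc2c(F)ccc3c2CCO3)n2cnnc12)c1ccccc1`: 3

In this assay compound 2 gives 3, the higher of the two numbers, and the nearest value belongs to compound 1 at 2.4. Compound 3 `O=C1CCCN1c1cnc(NCc2c(F)ccc3c2CCO3)n2cnnc12` is still unmeasured. It carries 2-oxopyrrolidin-1-yl in place of benzamido on an aromatic carbon of compound 2: 2-oxopyrrolidin-1-yl in place of benzamido on an aromatic carbon. For the measured compounds named here, one measured step bears on this, and only in part: a number 0.60 log units higher from compound 1 to compound 2 (beyond the scatter). That modest step, beyond the scatter, is hydrogen in place of methyl on an amide-type nitrogen. Going by the values given here, no measured step covers the exchange of the whole benzamido group, so the estimate is uncertain. A lower number is expected, in an estimated step somewhat larger than the one just described: a number 1.10 log units lower from compound 2 to compound 3 (beyond the scatter). For compound 3 the estimated value is 1.9, with an expected range of 1.3 to 2.5.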

Compound 3, distribution coefficient: 1.3
Compound 3: middle estimate off by 0.60 log units, on the high side, within the range that was stated.
By their numbers in this assay, from the lowest: compound 3; then compound 1; then compound 2.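

In this assay, the group para to a large group on the shared core proves highly responsive when the whole substituent is exchanged: a number 1.70 log units lower from compound 2 to compound 3 (beyond the scatter). The same exchange starting from the methylated amide gives a number 1.10 log units lower from compound 1 to compound 3 (beyond the scatter), so a large step appears even though neither compound 1 nor compound 3 carries the amide hydrogen. No measured evidence accounts for these steps.

The exchange changes several things at once, replacing a six-membered aromatic ring of carbon only with a five-membered non-aromatic ring and reducing the heavy-atom count, so the compounds shown do not separate these changes. From the compounds shown here alone, an acetamido group or a benzyl-substituted lactam at this position could help separate them, and how an amine or a carboxylic acid there would read in this assay remains open.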